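Swapping a nitrophenyl for furanyl at the hydrazone carbon

This account rests on a few compounds, and the source may have more. Where it says the series, first, only, none or still open, it means among the compounds named here.

Compound 1 `O=C(CSc1nnc(-c2ccncc2)o1)N/N=C/c1cccc(C(F)(F)F)c1` in an ADME assay on NIH3T3 cells (Mus musculus) for cytotoxicity, read by MTT assay, with a stated time of 24 h (on this read-out lower numbers stand for stronger inhibition and higher numbers for weaker inhibition), gives 169000 nM.
Compound 2 `O=C(CSc1nnc(-c2ccncc2)o1)N/N=C/c1ccccc1[N+](=O)[O-]` in this assay gives 214000 nM.
Compound 3 `O=C(CSc1nnc(-c2ccncc2)o1)N/N=C/c1ccccc1O` in this assay gives 155000 nM.

Three hydrazones sharing one core have been measured in this assay. Compound 2 gives the largest of the three numbers, yet its gaps to compound 1 and to compound 3 both lie within the scatter, so no order among them can be read. Among the compounds with values here, the only single-point step available, a 1.4-fold lower number from compound 2 to compound 3 (0.14 log units; within the scatter), exchanges one group on the aromatic ring and moves nothing beyond the noise.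

The unmeasured compound 4 `O=C(CSc1nnc(-c2ccncc2)o1)N/N=C/c1ccco1` differs from compound 2 by furan-2-yl in place of 2-nitrophenyl on a carbon with a double bond to nitrogen. Within the data shown here, no measured step exchanges the whole aromatic ring, so the nearest guide is the step from compound 2 to compound 3, which touched the same side of the molecule and stayed within scatter. On that basis no step beyond the scatter in this assay is expected, and compound 4 is estimated at 180000 nM, between 90000 nM and 360000 nM, a change of a 1.2-fold lower number from compound 2 to compound 4 (0.08 log units; within the scatter).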

Compound 4, half-maximal inhibitory concentration: 175000 nM
Compound 4: middle estimate off by 1.0-fold (0.01 log units), on the high side; the range from low to high includes it.
By their numbers in this assay, from the lowest: compounds 3, 1, 4 and 2 (each within the scatter of the next).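

In this assay, the change now reaches the whole aromatic group on the carbon with a double bond to nitrogen, not just one group on that ring. Furan-2-yl in place of 2-nitrophenyl gives a 1.2-fold lower number from compound 2 to compound 4 (0.09 log units; within the scatter) and furan-2-yl in place of 2-hydroxyphenyl gives a 1.1-fold higher number from compound 3 to compound 4 (0.05 log units; within the scatter) and neither step separates the five-membered ring from the six-membered rings it replaces. No available evidence bears on this result.

All the compounds shown carry an aromatic ring on this carbon, which leaves open whether an open chain such as an n-butyl group would give a step beyond the scatter. Also open, going by these compounds, is whether an amine or a carboxylic acid on the ring would do so.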